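Ring amine substituent change in a stability series

The source may report more compounds than this note shows. Statements on the series, on what has been measured and on what is new or still open speak of the compounds shown alone.

Compound 2 `CCOC(=O)C1=C(S[C@H]2C[C@@H](C(=O)Nc3cccc(C(=O)OCC)c3)N(C(=O)OCc3oc(=O)oc3C)C2)[C@H](C)[C@@H]2[C@@H]([C@@H](C)O)C(=O)N12` and compound 1 `C[C@@H](O)[C@H]1C(=O)N2C3=C(S[C@@H]4CN[C@@H](C4)C(=O)Nc4cccc(c4)C(=O)OC/C=C\COC3=O)[C@H](C)[C@H]12` share the core of this series. In an ADME assay for metabolic stability, read by LC-MS, with a stated time of 3 h, at pH 6.5, tested at 50 uM (on this read-out higher numbers stand for a more stable compound and lower numbers for a less stable compound), compound 2 gives > 95%, a limit of the assay and not a number. Compound 1 gives > 95% in this assay, again a limit. Both values sit at the limit of > 95% in this assay, at which 2 of the 2 values shown sit, so the two compounds cannot be told apart on this read-out. Compound 3 `CCOC(=O)C1=C(S[C@H]2C[C@@H](C(=O)Nc3cccc(C(=O)OCC)c3)N(Cc3oc(=O)oc3C)C2)[C@H](C)[C@@H]2[C@@H]([C@@H](C)O)C(=O)N12` carries a group of 8 heavy atoms (5 carbon, 3 oxygen; one five-membered aromatic ring with 2 hetero atoms) in place of a group of 11 heavy atoms (6 carbon, 5 oxygen; one five-membered aromatic ring with 2 hetero atoms), on an amine nitrogen in a ring. Among the measured compounds shown here, no measured step covers this change; no shift beyond the scatter is expected, with a number at least 3 percentage points lower from compound 2 to compound 3 (that floor lies within the scatter) as the expected step. For compound 3 the estimate is 92%, expected to fall within 75% to 99%.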

Compound 3, percent of the compound remaining: > 95%
Compound 3: only a limit was reported; the forecaster's own chance of this, stated with the estimate: 60%; middle value at least 3 percentage points from the limit.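

In this assay compound 3 gives > 95%, a limit and not a number. Among the compounds shown here, compound 2 also sits at a limit, so no step between compound 2 and compound 3 can be read: the limit of > 95% in this assay, at which 3 of the 3 values shown sit. The compounds shown leave open whether the group on the amine nitrogen in a ring changes the percent remaining at all.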